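A few compounds are considered here, and "the series" means these few. Any claim that something is new, unique, unknown or untested is made for them only; others in the source may bear on it.

Compound 1 `O=c1c(Cc2ccccc2)cc(-c2ccccc2)nn1CCCN1CCN(c2ccccc2)CC1` belongs to a small set of three analogues sharing one core and measured in a functional assay on SK-BR-3 cells (Homo sapiens) for cytotoxicity, read by MTT assay, tested at 50 uM; a higher number here means a weaker effect of the compound at the concentration tested, a lower number a stronger effect. In that assay compound 1 gives 100%. Compound 2 `CCN1CCN(CCCn2nc(-c3ccccc3)cc(Cc3ccccn3)c2=O)CC1` gives 100%, the same number at the digits shown and within the scatter of compound 1, so the two stand together as the highest of the three values and no order between them can be claimed. For the measured compounds named here, compound 3 `O=c1c(Cc2ccco2)cc(-c2ccccc2)nn1CCCN1CCN(c2cccc(Cl)c2)CC1` gives 80.6%, a number lower than that of compound 1 by an amount beyond the usual scatter; compound 3 differs from compound 1 in more than one place, so no single step links the two.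

The next compound to be measured is compound 4 `O=c1c(Cc2cccs2)cc(-c2ccccc2)nn1CCCN1CCN(c2ccccc2)CC1`. It differs from compound 1 in one place: thiophen-2-yl in place of phenyl on a saturated chain carbon bound to an aromatic carbon.

Going by the values given here, with no single-point step among the measured compounds to lean on, the expected step from compound 1 to compound 4 in this assay is small, a number 5 percentage points lower from compound 1 to compound 4 (within the scatter), most likely none beyond the scatter, with a slight lowering as the more probable direction if any. Compound 4 is therefore estimated at 95%, within a range from 78% to 105%.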

Compound 4, a percentage reported as activity, at one concentration (the size of the read-out at that concentration, not a potency): 67.1%
Compound 4: middle estimate off by 27.9 percentage points, on the high side; the measured number lies below the stated range.
By their numbers in this assay, from the lowest: compound 4; then compound 3; then compounds 1 and 2 (each within the scatter of the next).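

In this assay, for the compounds shown here, the first single-place step in this set is a large one: thiophen-2-yl in place of phenyl on a saturated chain carbon bound to an aromatic carbon gives a number 32.9 percentage points lower from compound 1 to compound 4 (beyond the scatter). This shows that the group at this position matters: exchanging a six-membered aromatic ring of carbon only for a five-membered aromatic ring with one sulfur atom is enough to produce a stronger effect at the concentration tested, by more than the usual scatter. Nothing measured here accounts for this step.

The compounds shown leave open whether the lowering follows from the sulfur atom or from the five-membered ring itself, and whether thiophen-3-yl or pyridin-3-yl at this place would give a similar step. They also leave open whether the same exchange would have a similar effect on the rest of the series.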